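Thiazolidinone series: dog microsomal clearance and the pyridin-2-yl change

The source may hold more compounds than are shown below. What is called first, only, known or untested is meant among the compounds shown, and "the series" means these compounds.

Three compounds of the shared core have been run in an ADME assay on microsomes from liver (Canis lupus familiaris) for metabolic stability, read by LC-MS, using NADPH, with a stated time of 10 min, tested at 0.1 uM; on this read-out higher numbers stand for fast clearance and lower numbers for slow clearance. Compound 1 `O=C(NCCCCc1ccccc1)c1cccc(C2SCC(=O)N2c2cccc(-c3c[nH]nn3)c2)c1` gives 226 mL.min-1.g-1, the lowest of the three numbers. Compound 3 `COc1ccc(F)cc1N1C(=O)CSC1c1cccc(C(=O)NCCCCn2cccn2)c1` gives 480 mL.min-1.g-1, a higher number that lies beyond the scatter of this assay. Compound 2 `COc1ccccc1N1C(=O)C(C)SC1c1cccc(C(=O)NCCCCc2ccccc2)c1` gives 1170 mL.min-1.g-1, the highest of the set and also beyond the scatter from compound 1. The three differ in more than one place, so no single step can be read from them; only their values stand.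

Compound 4 `O=C(NCCCCc1ccccc1)c1cccc(C2SCC(=O)N2c2ccccn2)c1` has not been measured in this assay. It differs from compound 1 by a group of 6 heavy atoms (5 carbon, 1 nitrogen; one six-membered aromatic ring with 1 hetero atom) in place of a group of 11 heavy atoms (8 carbon, 3 nitrogen; one five-membered aromatic ring with 3 hetero atoms, one six-membered aromatic ring of carbon only), on an amide-type nitrogen in a ring. The group that leaves carries the one hydrogen-bond donor of that part of the molecule and two acceptors; the group that enters carries one acceptor and no donor, and is smaller by the counts given.

For the measured compounds named here, no pair of measured compounds shows this change, so the expectation rests on the range of values seen. Compound 1 is the low end of that range, and the move to a smaller group without the donor is expected to push the number up rather than down, by a modest step, a 1.9-fold higher number from compound 1 to compound 4 (0.27 log units; within the scatter), close to the edge of the scatter. Compound 4 is therefore estimated at 420 mL.min-1.g-1, within a range from 180 mL.min-1.g-1 to 950 mL.min-1.g-1.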

Compound 4, intrinsic clearance in microsomes: 492 mL.min-1.g-1
The estimate for compound 4 lay 1.2-fold (0.07 log units) below the measured number; the range from low to high includes it.
By their numbers in this assay, from the lowest: compound 1; then compounds 3 and 4 (each within the scatter of the next); then compound 2.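

For the compounds shown here, at the amide-type nitrogen in a ring, two ring bonds from the ring sulfur, placing pyridin-2-yl where compound 1 carries its larger group gives, in this assay, a 2.2-fold higher number from compound 1 to compound 4 (0.34 log units; beyond the scatter) and this is the first comparison that differs in one place only. The number at this position therefore moves beyond the scatter with the rest of compound 1 held constant, although the step is modest and compound 4 does not approach the top of the range set by compound 2 at 1170 mL.min-1.g-1 in a comparison that cannot be read as a single change. No measurement accompanying this result bears on why the number moves.

The change alters the size of the group, its ring types and its hydrogen-bond donor together, and this single pair cannot separate those features. As far as these compounds go, whether a plain phenyl, or a phenyl carrying a carboxylic acid, on the same nitrogen would give a number nearer that of compound 1 or that of compound 4 remains open.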